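The source may report more compounds than this note shows. Statements on the series, on what has been measured and on what is new or still open speak of the compounds shown alone.

Three compounds share one core and differ only in the group carried on one aromatic carbon of that core. Compound 1 `COc1cc(-c2ccnc3cc(-c4ccccc4)nn23)cc(OC)c1OC` bears a phenyl there, and in a functional assay on HeLa cells (Homo sapiens) for inhibition, read by CCK-8 assay, with a stated time of 48 h (a higher number here means a weaker inhibitor, a lower number a stronger inhibitor), compound 1 gives 458 nM. Compound 2 `COc1cc(-c2ccnc3cc(-c4ccc5cc[nH]c5c4)nn23)cc(OC)c1OC` bears a 1H-indol-6-yl, and in this assay compound 2 gives 125 nM. Compound 3 `COc1cc(-c2ccnc3cc(-c4cn(C)c5ccccc45)nn23)cc(OC)c1OC` bears a 1-methyl-1H-indol-3-yl, and in this assay compound 3 gives 399 nM. Compound 3 therefore holds the second highest of the three numbers, though a 1.1-fold lower number from compound 1 to compound 3 (0.06 log units; within the scatter) keeps it within the scatter of compound 1, while a 3.2-fold higher number from compound 2 to compound 3 (0.50 log units; beyond the scatter) and a 3.7-fold lower number from compound 1 to compound 2 (0.56 log units; beyond the scatter) set compound 2 apart.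

Compound 4 `COc1ccc(-c2cc3nccc(-c4cc(OC)c(OC)c(OC)c4)n3n2)cc1N` has not yet been measured. It differs from compound 3 in this way: 3-amino-4-methoxyphenyl in place of 1-methyl-1H-indol-3-yl on an aromatic carbon. For the measured compounds named here, no measured step swaps exactly this pair. The nearest guides are a 1.1-fold lower number from compound 1 to compound 3 (0.06 log units; within the scatter), where the 1-methyl-1H-indol-3-yl and phenyl gave much the same number, and a 3.7-fold lower number from compound 1 to compound 2 (0.56 log units; beyond the scatter), where a group with one hydrogen-bond donor in place of phenyl went with a lower number. The incoming group also carries one hydrogen-bond donor, so a modest lower number is expected, a 1.6-fold lower number from compound 3 to compound 4 (0.20 log units; within the scatter). For compound 4 in this assay the estimate is 250 nM, most likely between 80 nM and 800 nM.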

Compound 4, half-maximal inhibitory concentration: 283 nM
For compound 4 the middle estimate is 1.1-fold (0.05 log units) below the measured one; low and high end bracket the measured number.
By their numbers in this assay, from the lowest: compound 2; then compounds 4, 3 and 1 (each within the scatter of the next).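

The 3-amino-4-methoxyphenyl carries a hydrogen-bond donor, as the 1H-indol-6-yl does, yet in this assay the two do not match: there is a 2.3-fold higher number from compound 2 to compound 4 (0.35 log units; beyond the scatter), so among these compounds a donor in this place does not by itself go with the number of compound 2. For the compounds shown here, the new group also stays close to both groups without a donor, with a 1.6-fold lower number from compound 1 to compound 4 (0.21 log units; within the scatter) and a 1.4-fold lower number from compound 3 to compound 4 (0.15 log units; within the scatter), which leaves the 1H-indol-6-yl as the only group here set apart from the phenyl. No measurement is available to explain this difference.

Still open, going by these compounds, is whether the hydrogen on the indole nitrogen matters, which a 1-methyl-1H-indol-6-yl would test. A 3-aminophenyl and a 4-methoxyphenyl would separate the amine from the methoxy.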